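This account rests on a few compounds, and the source may have more. Where it says the series, first, only, none or still open, it means among the compounds named here.

In a functional assay on HepG2 cells (Homo sapiens) for inhibition, read by MTT assay, with a stated time of 48 h (a lower number here means a stronger inhibitor, a higher number a weaker inhibitor), three compounds have been measured so far. Compound 1 (`COc1ccc(CSc2nnc(-c3cc(OC)c(OC)c(OC)c3)n2-c2ccc(OC)cc2)cc1`) gives 41100 nM. Compound 2 (`COc1cc(-c2nnc(SC)n2-c2ccc(N(C)C)cc2)cc(OC)c1OC`) gives > 60000 nM, which is a limit and not a number. Compound 3 (`COc1cc(-c2nnc(SCc3ccccc3)n2-c2ccc(N(C)C)cc2)cc(OC)c1OC`) gives > 60000 nM, which is also only a limit. The series therefore shows (the limit of > 60000 nM in this assay, at which 2 of the 3 values shown sit), and compound 3 has no readable place on the scale.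

Compound 4 (`COc1ccc(CSc2nnc(-c3cc(OC)c(OC)c(OC)c3)n2-c2ccc(N(C)C)cc2)cc1`) alters compound 3 at a single place, turning benzyl into 4-methoxybenzyl: methoxy in place of hydrogen on an aromatic carbon. Among the measured compounds shown here, the one measured step, a step that the two limits leave unreadable from compound 2 to compound 3, offers no size to carry over. The nearest guide is compound 1, which carries the same 4-methoxybenzyl group and gives 41100 nM. A weak inhibitor is therefore expected again, with no firm direction for the change. The expected size is only a rough estimate, an at least 1.0-fold lower number from compound 3 to compound 4 (0.03 log units; that floor lies within the scatter), and the assay may well report a limit instead of a number. Compound 4 is estimated at 55000 nM, with an expected range of 25000 nM to 110000 nM.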

Compound 4, half-maximal inhibitory concentration: > 60000 nM
Compound 4: no number, only a limit; the forecaster's own chance of this, stated with the estimate: 55%; middle value at least 1.0-fold (0.03 log units) from the limit.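

Methoxy in place of hydrogen on the aromatic carbon, the 4-methoxybenzyl group that compound 1 also carries, does not bring the dimethylamino compounds to a readable number in this assay: the limit of > 60000 nM in this assay, at which 3 of the 4 values shown sit. On these data alone, the steps from compound 3 and from compound 2 to compound 4 cannot be read, as both ends of each are limits, so the size of the methoxy change stays unknown. The one readable step, dimethylamino in place of methoxy on an aromatic carbon, is an at least 1.4-fold higher number from compound 1 to compound 4 (0.16 log units; that floor lies within the scatter), so the two compounds are not shown to differ.

As far as these compounds go, whether a chlorine or a hydroxyl in place of the methoxy would give a readable number for the benzyl series stays open. So does whether a carboxylic acid at that place would change the picture.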